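This account rests on a few compounds, and the source may have more. Where it says the series, first, only, none or still open, it means among the compounds named here.

Measured in a functional assay on HEK293 cells (Homo sapiens) for cytotoxicity; on this read-out higher numbers stand for lower toxicity in this test and lower numbers for higher toxicity in this test
Compound 1 `COc1ccc(OC)c(S(=O)(=O)Nc2cccc(N3C[C@@H](c4ccc(OC)c(OC5CCCC5)c4)CC3=O)c2)c1` gives 7590 nM
Compound 2 `COc1ccc([C@H]2CC(=O)N(c3cccc(NS(=O)(=O)c4ccc(F)cc4)c3)C2)cc1OC1CCCC1` gives > 10000 nM as a limit

Compound 2 stands at > 10000 nM as a limit of the assay, not a number. Compound 3 `COc1ccc([C@H]2CC(=O)N(c3cccc(NS(=O)(=O)c4c(F)cccc4F)c3)C2)cc1OC1CCCC1` differs by 2,6-difluorophenyl in place of 4-fluorophenyl on a sulfonyl sulfur and carries 2,6-difluorophenyl in place of 4-fluorophenyl on a sulfonyl sulfur. Within the data shown here, the one measured step at this place is an at least 1.3-fold higher number from compound 1 to compound 2 (0.11 log units; that floor lies within the scatter) and its floor lies within the scatter. No change beyond the scatter is therefore expected in this assay and the estimated step is a step that the limit leaves unreadable from compound 2 to compound 3 in size. For compound 3 the estimate is 11000 nM with 5000 nM to 25000 nM as the expected range.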

Compound 3, half-maximal cytotoxic concentration: > 10000 nM
Compound 3: a limit, no number (the forecaster's own chance of this, stated with the estimate: 70%); the middle value does not contradict the limit.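

In this assay compound 3 reads > 10000 nM, a limit of the assay and not a number, so 2,6-difluorophenyl on the sulfonyl sulfur gives no readable value, just as 4-fluorophenyl did not. The change from 2,5-dimethoxyphenyl to 2,6-difluorophenyl gives an at least 1.3-fold higher number from compound 1 to compound 3 (0.11 log units; that floor lies within the scatter). The step between the two fluorinated compounds cannot be read, since both sit at the limit: the limit of > 10000 nM in this assay, at which 2 of the 3 values shown sit.

As far as these compounds go, how far compound 2 and compound 3 lie past that limit stays open. Also open, from the compounds shown here alone, is how an amine or a carboxylic acid on the aromatic ring at this place would read in this assay.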